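A few compounds are considered here, and "the series" means these few. Any claim that something is new, unique, unknown or untested is made for them only; others in the source may bear on it.

Compounds measured in a functional assay on HCT-116 cells (Homo sapiens) for cytotoxicity, read by MTT assay, with a stated time of 48 h; a higher number here means a weaker inhibitor, a lower number a stronger inhibitor:
- compound 1, `COc1ccc(N/C=C\C(=O)c2nc(-c3ccc(F)cc3)n3ccccc23)cc1OC` — in this assay compound 1 gives > 30000 nM, which is a limit of the assay and not a number.
- compound 2, `COc1ccc(N/C=C\C(=O)c2nc(-c3ccc(F)cc3)n3ccccc23)cc1` — in this assay compound 2 gives > 30000 nM, again a limit of the assay.

Compound 2 thus stands at the limit of this assay, with no measured number to place it. Within the data shown here, the one measured step, a step that the two limits leave unreadable from compound 1 to compound 2, cannot be read, since both its ends sit at that same limit; the only evidence on the series is the limit of > 30000 nM in this assay, at which 2 of the 2 values shown sit.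

Compound 3, `O=C(/C=C\Nc1ccc(Cl)cc1)c1nc(-c2ccc(F)cc2)n2ccccc12`, differs from compound 2 by chloro in place of methoxy on an aromatic carbon. Among the measured compounds shown here, the measured step bears on it only in that the one exchange on this aromatic carbon so far left both ends unreadable at the limit, so no direction can be drawn from it. The expectation is therefore that compound 3 shows no step beyond the scatter, a step that the limit leaves unreadable from compound 2 to compound 3, and most likely also returns only a limit. The estimate for compound 3 in this assay is 40000 nM, within a range from 15000 nM to 100000 nM.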

Compound 3, half-maximal inhibitory concentration: 1210 nM
Estimate against measurement, compound 3: 33-fold (1.52 log units) above; the whole stated range lies above it.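

Among these compounds, this position, on an aromatic carbon para to a large group, gives the first readable number of the series in this assay: chloro in place of methoxy gives an at least 24-fold lower number from compound 2 to compound 3 (1.39 log units; beyond the scatter) and so separates two compounds that differ in one place. Measured against the dimethoxy end of the series, 4-chlorophenyl in place of 3,4-dimethoxyphenyl on the amine nitrogen gives an at least 24-fold lower number from compound 1 to compound 3 (1.39 log units; beyond the scatter) and reaches the same compound 3 from a second direction. As far as these compounds go, both sizes are minimum sizes, and the true gaps stay unknown, since the methoxy end of each step is a limit of the assay and not a number: the limit of > 30000 nM in this assay, at which 2 of the 3 values shown sit.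

From the compounds shown here alone, it remains open whether the gain belongs to chloro itself or follows from the loss of methoxy, which only hydrogen, fluoro, bromo or trifluoromethyl at the same place could separate. Also open, going by these compounds, is how far this position tolerates a larger or ionisable group such as a dimethylamino group or a carboxylic acid, and whether 3,4-dichlorophenyl on the amine nitrogen would go further than 4-chlorophenyl.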